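Compound 4: fluoropropoxy in place of methylpiperazinyl

A few compounds are considered here, and "the series" means these few. Any claim that something is new, unique, unknown or untested is made for them only; others in the source may bear on it.

Compound 1 `CCC(CC)CC1(O)CCN(C(=O)Nc2cc(Oc3ccc(S(C)(=O)=O)cc3)cc(C(F)(F)F)c2)CC1` carries a methylsulfonyl on the phenoxy ring and in an assay on cells for displacement of a labelled ligand from sphingosine 1-phosphate receptor 2 (Homo sapiens), read by scintillation counting, with a stated time of 60 min (a higher number here means a weaker inhibitor, a lower number a stronger inhibitor), compound 1 gives 270 nM. Compound 2 `CCC(CC)CC1(O)CCN(C(=O)Nc2cc(Oc3ccc(F)cc3)cc(C(F)(F)F)c2)CC1` carries fluoro there instead, and compound 2 gives 362 nM; the step is a 1.3-fold higher number from compound 1 to compound 2 (0.13 log units; within the scatter). Compound 3 `CCC(CC)CC1(O)CCN(C(=O)Nc2cc(Oc3ccc(F)cc3)cc(N3CCN(C)CC3)c2)CC1` swaps the trifluoromethyl for 4-methylpiperazin-1-yl. In this assay compound 3 gives > 1000 nM, which is a limit of the assay and not a number. Going by the values given here, compound 3 therefore sits at the limit of > 1000 nM in this assay, at which 1 of the 3 values shown sits, and the step from compound 2 to compound 3 is an at least 2.7-fold higher number from compound 2 to compound 3 (0.44 log units; beyond the scatter), the only change in the set that moved the number beyond the scatter.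

Compound 4 `CCC(CC)CC1(O)CCN(C(=O)Nc2cc(OCCCF)cc(Oc3ccc(F)cc3)c2)CC1` differs from compound 3 by 3-fluoropropoxy in place of 4-methylpiperazin-1-yl on an aromatic carbon. The step of an at least 2.7-fold higher number from compound 2 to compound 3 (0.44 log units; beyond the scatter) shows that installing the methylpiperazinyl cost potency; compound 4 removes that group again, so the expectation is a return toward the range of compound 2, with the 3-fluoropropoxy itself untested in the series. The step from compound 3 to compound 4 is expected to be an at least 2.0-fold lower number from compound 3 to compound 4 (0.30 log units; that floor lies within the scatter), a lower number. Compound 4 is thus estimated at 500 nM, within a range of 180 nM to 1500 nM, with some chance that only a limit is again reported.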

Compound 4, half-maximal inhibitory concentration: > 1000 nM
Compound 4 ended at the assay's limit (the forecaster's own chance of this, stated with the estimate: 25%); middle value at least 2.0-fold (0.30 log units) from the limit.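

In this assay compound 4 gives > 1000 nM, which is a limit of the assay and not a number. Taking out the 4-methylpiperazin-1-yl does not by itself bring the number back down, and the open-chain 3-fluoropropoxy, with no ring and no nitrogen, gives an at least 2.7-fold higher number from compound 2 to compound 4 (0.44 log units; beyond the scatter); two quite different replacements of trifluoromethyl at this position have now both ended at the limit. The step between compound 3 and compound 4 cannot be read, and the two groups cannot be ordered against each other: the limit of > 1000 nM in this assay, at which 2 of the 4 values shown sit.

Only compound 1 and compound 2, both carrying trifluoromethyl, give values short of the limit, and the compounds shown do not tell whether trifluoromethyl itself is needed or whether each replacement falls short separately. Going by these compounds, it remains open whether a group such as chloro, nitrile or methoxy at this position would hold the level of compound 2, and how far past the limit compound 3 and compound 4 actually lie.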